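The source may hold more compounds than are shown below. What is called first, only, known or untested is meant among the compounds shown, and "the series" means these compounds.

Measured in a functional assay on PC-3 cells (Homo sapiens) for cytotoxicity, read by sulforhodamine B assay, with a stated time of 5 days; on this read-out lower numbers stand for stronger inhibition and higher numbers for weaker inhibition:
Compound 1 `O=C(CCCCCCCCCCCc1ccccc1)CC(=O)N[C@H]1CCOC1=O` gives 4000 nM
Compound 3 `O=C(CCCCCCCCCCc1ccccc1)CC(=O)N[C@H]1CCOC1=O` gives 2000 nM
Compound 2 `O=C(CCCc1ccccc1)CC(=O)N[C@H]1CCOC1=O` gives > 100000 nM as a limit of the assay

Only compound 1 and compound 3 give true numbers, and the two stand level, with a 2.0-fold lower number from compound 1 to compound 3 (0.30 log units; within the scatter) for phenyl in place of benzyl. Compound 2 sits at a limit, as the limit of > 100000 nM in this assay, at which 1 of the 3 values shown sits, records.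

Compound 4 `O=C(CCCCCCCCc1ccccc1)CC(=O)N[C@H]1CCOC1=O` keeps the shared core but changes the chain end: phenyl in place of phenethyl on a saturated chain carbon, eight bonds along the chain from a carbonyl carbon. In words, this is phenyl in place of phenethyl on a saturated chain carbon, eight bonds along the chain from a carbonyl carbon.

The closest measured precedent is a 2.0-fold lower number from compound 1 to compound 3 (0.30 log units; within the scatter), which suggests little change. That step removes less of the chain, however, and compound 2 stays a caution with its limit of > 100000 nM. A moderate rise in the number is therefore expected in this assay, near the edge of the scatter or somewhat beyond it.

The expected step is a 3.0-fold higher number from compound 3 to compound 4 (0.48 log units; beyond the scatter).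

Compound 4 is estimated at 6000 nM, with an expected range of 2000 nM to 30000 nM.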

Compound 4, half-maximal inhibitory concentration: 4000 nM
Compound 4: the middle estimate sits 1.5-fold (0.18 log units) above what was measured; the range from low to high includes it.
By their numbers in this assay, from the lowest: compounds 3, 1 and 4 (each within the scatter of the next). At a limit, above all of these: compound 2.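

In this assay, phenyl in place of phenethyl, on a saturated chain carbon, eight bonds along the chain from a carbonyl carbon, gives a 2.0-fold higher number from compound 3 to compound 4 (0.30 log units; within the scatter), and phenyl in place of 3-phenylpropyl at the same place gives no change at the digits printed from compound 1 to compound 4 (within the scatter). Among these compounds, compound 1, compound 3 and compound 4 thus stand level, which shows that this chain can be cut back further than the one earlier step could show without a change beyond the scatter. Compound 2 goes against this level and is known only as a limit: the limit of > 100000 nM in this assay, at which 1 of the 4 values shown sits.

The compounds shown leave open at what chain length between compound 4 and compound 2 the number leaves this level. They also leave open whether a longer chain, or a carboxylic acid or an amine in place of the phenyl, would hold it.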